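This account rests on a few compounds, and the source may have more. Where it says the series, first, only, none or still open, it means among the compounds named here.

Measured so far in a physicochemical assay for lipophilicity; on this read-out higher numbers stand for higher lipophilicity and lower numbers for lower lipophilicity:

- Compound 1 `CCC1C[N+]2(c3ccnc4ccc(OC(C)CO)cc34)CCC1CC2`: 2.31
- Compound 2 `OC(CC1CCCCN1)c1ccnc2ccccc12`: 0.05
- Compound 3 `Cc1ccc(Oc2cc(C(O)CC3CCCCN3)c3ccccc3n2)cc1`: 2.69

Of these three, compound 3 has the highest number, with compound 1 and compound 2 both lower by more than the scatter. Compound 4 `Cc1ccc(Oc2cc(C(O)CC3CCCCN3)c3cc(Cl)ccc3n2)cc1` differs from it in one place: chloro in place of hydrogen on an aromatic carbon. Among the measured compounds shown here, the only measured step that bears on this is a number 2.64 log units higher from compound 2 to compound 3 (beyond the scatter), which came with 4-methylphenoxy in place of hydrogen on an aromatic carbon. For the measured compounds named here, no measured step involves chloro itself, so that step is only a loose guide. A rise in this assay is expected, beyond the scatter but far smaller. The estimated change is a number 0.61 log units higher from compound 3 to compound 4 (beyond the scatter). For compound 4 the expected value is 3.3, with an estimated range of 2.9 to 3.8.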

Compound 4, partition coefficient: 3.4
Estimate against measurement, compound 4: 0.10 log units below, and the stated range covers the measured number.
By their numbers in this assay, from the lowest: compound 2; then compound 1; then compound 3; then compound 4.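

In this assay, chloro in place of hydrogen on an aromatic carbon, meta to a fused ring and para to a fused ring, gives a number 0.71 log units higher from compound 3 to compound 4 (beyond the scatter). So even with the 4-methylphenoxy group already in place, this single added atom still moves the number by more than the scatter, though the step is smaller than a number 2.64 log units higher from compound 2 to compound 3 (beyond the scatter). Nothing available here explains the size of this rise.

Going by these compounds, whether fluoro, methoxy or an amine at this position would raise or lower the number remains open. So does whether chloro gives a similar step without the 4-methylphenoxy group.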